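This account rests on a few compounds, and the source may have more. Where it says the series, first, only, none or still open, it means among the compounds named here.

The study measured two compounds in a functional assay on U-251 cells (Homo sapiens) for inhibition, read by sulforhodamine B assay, with a stated time of 48 h, tested at 10 uM (on this read-out higher numbers stand for a weaker effect at the one concentration tested and lower numbers for a stronger effect), and left a third to be measured. Compound 1 `COc1cc(Cl)cc(-c2nn(-c3cccc(NC(=O)c4ccc(Cl)c(Cl)c4)c3)cc2-c2ccncc2)c1` gives 64.1% in this assay. Compound 2 `O=C(Nc1cccc(-n2cc(-c3ccncc3)c(-c3cc(O)cc(Cl)c3)n2)c1)Nc1ccc(Cl)c(C(F)(F)F)c1` gives -26.5% in this assay, the lower of the two numbers shown, and the gap to compound 1 is beyond the usual scatter, so compound 2 shows the stronger effect of the pair. Compound 3 `O=C(Nc1cccc(-n2cc(-c3ccncc3)c(-c3cc(O)cc(Cl)c3)n2)c1)Nc1ccc(Cl)c(Cl)c1` differs from compound 2 in one place: chloro in place of trifluoromethyl on an aromatic carbon. Among the compounds with values here, no pair of measured compounds differs in just one place, so nothing known directly tells how large such a step is. The change keeps the rest of compound 2 intact, and the expected step in this assay from compound 2 to compound 3 is small, at most a modest rise in the number, a number 16.5 percentage points higher from compound 2 to compound 3 (beyond the scatter). On that basis compound 3 is estimated at -10% in this assay, with a range from -40% to 30%.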

Compound 3, a percentage reported as activity, at one concentration (the size of the read-out at that concentration, not a potency): -56.5%
Beside the measured number, compound 3's estimate is 46.5 percentage points above it; the measured number lies below the stated range.
By their numbers in this assay, from the lowest: compound 3; then compound 2; then compound 1.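

In this assay, within the data shown here, the 4-chloro-3-(trifluoromethyl)phenyl group giving way to 3,4-dichlorophenyl yields a number 30 percentage points lower from compound 2 to compound 3 (beyond the scatter), the first direct reading of a single change in this set. At this place, ortho to a chloro group and meta to a large group, one heavy atom in chloro therefore takes over from the four of trifluoromethyl with a stronger effect, not a weaker one, so the full trifluoromethyl group is not needed for the effect seen with compound 2. No measurement shown here accounts for the direction or size of this step.

The compounds shown leave open how a methyl group, a bromo group or a plain hydrogen would read at this same place. Among these compounds, they also leave open whether the change from trifluoromethyl to chloro gives a step of like size on any other core, as this is the only pair here that differs in one place.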